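The compounds below may be only part of what the source reports. "The series", "measured", "known", "first", "only" and "open" are said of these compounds alone.

Measured so far in an ADME assay on MT4 cells (Homo sapiens) for cytotoxicity, read by MTT assay, with a stated time of 4 days; a lower number here means that less compound is tolerated, a higher number that more compound is tolerated:
compound 1 `O=C(N/N=C/c1cccc(Cl)c1)c1cccnc1`: 62 ug/mL
compound 2 `O=C(N/N=C/c1ccc(Cl)cc1)c1cccnc1`: 76 ug/mL
compound 3 `O=C(N/N=C/c1cccc(Br)c1)c1cccnc1`: 66 ug/mL

The three measured values of this assay lie within the usual scatter of one another, so no ordering among compound 1, compound 2 and compound 3 is claimed. Compound 1 and compound 3 differ in one place: bromo in place of chloro on an aromatic carbon. That change gave a 1.1-fold higher number from compound 1 to compound 3 (0.03 log units; within the scatter), a step inside the scatter. Compound 2 is built from the same atoms as compound 1, joined differently; the difference between the two cores is not broken down here.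

Not yet measured is compound 4 `O=C(N/N=C/c1ccc(Br)cc1)c1cccnc1`. It differs from compound 2 in one place: bromo in place of chloro on an aromatic carbon. Among the compounds with values here, this is the same kind of change as the one from compound 1 to compound 3, but not the same change, since around the place the group sits meta to a large group in the first pair and para to a large group in the second pair.

Within the data shown here, the expectation for compound 4 rests on the single measured example of this kind of change, the step from compound 1 to compound 3 of a 1.1-fold higher number from compound 1 to compound 3 (0.03 log units; within the scatter), which was within the scatter. The step from compound 2 to compound 4 is therefore expected to be of similar size, a 1.1-fold higher number from compound 2 to compound 4 (0.02 log units; within the scatter), and to stay within the scatter. Compound 4 is estimated at 80 ug/mL in this assay, with a range from 55 ug/mL to 115 ug/mL.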

Compound 4, half-maximal cytotoxic concentration: 61 ug/mL
Compound 4: middle estimate off by 1.3-fold (0.12 log units), on the high side; the range from low to high includes it.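

In this assay, bromo in place of chloro on an aromatic carbon, para to a large group, gave a 1.2-fold lower number from compound 2 to compound 4 (0.10 log units; within the scatter), so this step adds a second small result for the exchange of these two halogens. Set beside the earlier step, the result gives no sign that the outcome of this change depends on the core: the same change on two cores in this assay, a 1.1-fold higher number (0.03 log units; within the scatter) from compound 1 to compound 3 and a 1.2-fold lower number (0.10 log units; within the scatter) from compound 2 to compound 4, 1.3-fold (0.12 log units) apart, within the scatter of two such steps. This shows only that, in these two pairs, the exchange produced no step beyond the scatter and that no direction can be read from either step; it does not establish a rule for other cores or other groups, and two pairs cannot reveal a small dependence on the core or on where the halogen sits.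

The compounds shown carry only chloro or bromo on the carbon-only aromatic ring, which leaves open whether an amine, a carboxylic acid, a methoxy group or a longer chain in the same places would move the number beyond the scatter. Also open, on these data alone, are how the exchange behaves after changes elsewhere in the shared core, and whether the same picture would hold in any assay other than this assay.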